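Cyano in Place of Methyl: From Compound 1 to Compound 3

The compounds below may be only part of what the source reports. "The series", "measured", "known", "first", "only" and "open" are said of these compounds alone.

Measured compounds:
compound 1, `Cc1ccc(COc2nc3ccccc3s2)cc1`: "not active" (no number reported)
compound 2, `Fc1ccccc1COc1nc2ccccc2s1`: 51.9%

In a functional assay on the whole organism with Mus musculus as the target, in the writhing test, at a dose of 100 mg/kg by the intraperitoneal route (a higher number here means more inhibition at the dose given (going by the name of the read-out), a lower number less inhibition), compound 1 gives "not active" (no number reported), so no single number marks where it stands. In this assay compound 2 gives 51.9%. Compound 3, `N#Cc1ccc(COc2nc3ccccc3s2)cc1`, differs from compound 1 in one place: cyano in place of methyl on an aromatic carbon. For the measured compounds named here, no step between measured compounds is available, so the change from compound 1 to compound 3 cannot be read from a measured pair. A step upward of modest size, possibly beyond the scatter, is expected, as compound 1 has no reported activity. Compound 3 is estimated in this assay at 30%, with a range from 0% to 60%.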

Compound 3, a percentage reported as inhibition, in the whole organism at one dose (the size of the read-out at that dose, not a potency): "not active" (no number reported)
Compound 3 has no reported number here; there is nothing to compare the estimate with.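

In this assay, for the compounds shown here, compound 1 gives "not active" (no number reported) and compound 3 gives "not active" (no number reported) so no step from compound 1 to compound 3 can be read. No further data bear on this result. The compounds shown leave open whether cyano in place of methyl changes the inhibition at all.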